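Urea aryl swap at the amide nitrogen of compound 1

The source may report more compounds than this note shows. Statements on the series, on what has been measured and on what is new or still open speak of the compounds shown alone.

Measured so far:
compound 1, `Nc1n[nH]c2cccc(-c3cccc(NC(=O)Nc4ccc(Cl)cc4Cl)c3)c12`: 1900 nM
compound 2, `Nc1n[nH]c2cccc(-c3cccc(NC(=O)Nc4ccccc4F)c3)c12`: 2360 nM

Both compounds share a core and differ only in the aryl group on the urea nitrogen. In a functional assay on SMMC-7721 cells (Homo sapiens) for inhibition, read by MTT assay, with a stated time of 48 h (a higher number here means a weaker inhibitor, a lower number a stronger inhibitor), compound 1 gives 1900 nM, the lowest of the two numbers shown, though compound 2 lies within the scatter of it, so no order between them can be claimed. For the measured compounds named here, the one step known here, a 1.2-fold higher number from compound 1 to compound 2 (0.09 log units; within the scatter), shows that exchanging one aryl group for another on this nitrogen left the read-out essentially where it was.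

Compound 3, `Cc1ccc(NC(=O)Nc2cccc(-c3cccc4[nH]nc(N)c34)c2)cc1`, is not yet measured. It differs from compound 1 as follows: 4-methylphenyl in place of 2,4-dichlorophenyl on an amide-type nitrogen. Going by the values given here, this is the same kind of exchange on the same nitrogen as the one step already seen, and that step stayed within the scatter. On that basis the number for compound 3 in this assay is expected to stay close to that of compound 1, with a 1.3-fold higher number from compound 1 to compound 3 (0.12 log units; within the scatter) as the estimated step. The estimated value for compound 3 is 2500 nM, within a range from 1100 nM to 5500 nM.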

Compound 3, half-maximal inhibitory concentration: 4450 nM
Beside the measured number, compound 3's estimate is 1.8-fold (0.25 log units) below it; the measured number falls inside the stated range.
By their numbers in this assay, from the lowest: compounds 1, 2 and 3 (each within the scatter of the next, the first and the last beyond it).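

In this assay, for the compounds shown here, the aryl group on this amide-type nitrogen proves not to be freely exchangeable: 4-methylphenyl in place of 2,4-dichlorophenyl gives the only step at this nitrogen printed as beyond the scatter (a 2.3-fold higher number from compound 1 to compound 3 (0.37 log units; beyond the scatter)), though that step is modest. The step from the 2-fluorophenyl group to the same 4-methylphenyl group stays within the scatter (a 1.9-fold higher number from compound 2 to compound 3 (0.28 log units; within the scatter)), so compound 2 cannot be separated from either compound 1 or compound 3, and only those last two stand apart. No measurement is available that would account for the gap between compound 1 and compound 3.

The exchange from compound 1 to compound 3 removes both chlorine atoms and adds a methyl group in one step, so the compounds shown cannot tell which part of it goes with the higher number. Going by these compounds, an unsubstituted phenyl group or a 4-chlorophenyl group on this nitrogen would divide that exchange into smaller parts, and a group carrying an amine or a carboxylic acid remains untested here, as does any change elsewhere on the shared core.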